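Compound 3 to compound 4: an aryl swap on the amide

The source may report more compounds than this note shows. Statements on the series, on what has been measured and on what is new or still open speak of the compounds shown alone.

Compound 1 `O=C1Nc2ccc([N+](=O)[O-])cc2/C1=C\C(=O)c1ccc(C2CCCCC2)cc1`: 2090 nM
Compound 2 `O=C1Nc2ccc(F)cc2/C1=C\C(=O)c1cccs1`: 2750 nM
Compound 3 `COc1ccc(C(=O)Nc2ccc3c(c2)/C(=C/Nc2cccc(N4CCN(C)CC4)c2)C(=O)N3)cc1`: 2050 nM

All three values come from a functional assay on A2780 cells (Homo sapiens) for inhibition, read by sulforhodamine B assay, with a stated time of 3 days; on this read-out lower numbers stand for stronger inhibition and higher numbers for weaker inhibition. Compound 3 stands within the scatter of both compound 1 and compound 2, so these numbers set no order among the three. Compound 4 `CN1CCN(c2cccc(N/C=C3\C(=O)Nc4ccc(NC(=O)c5cccc(F)c5)cc43)c2)CC1` has not yet been measured. It carries 3-fluorophenyl in place of 4-methoxyphenyl on a carbonyl carbon. Within the data shown here, no measured pair differs in one place, so the data do not show what this swap does. Among the measured compounds shown here, the only anchor is compound 3 at 2050 nM, the measured compound that shares the rest of the structure with compound 4. No change beyond the scatter is expected in this assay, and no direction is favoured with any confidence. The estimated step of a 1.1-fold lower number from compound 3 to compound 4 (0.06 log units; within the scatter) is expected to remain within the scatter. For compound 4 the expected value is 1800 nM, with an estimated range of 600 nM to 5000 nM.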

Compound 4, half-maximal inhibitory concentration: 2910 nM
For compound 4 the middle estimate is 1.6-fold (0.21 log units) below the measured one; measured number inside the range.
By their numbers in this assay, from the lowest: compounds 3, 1, 2 and 4 (each within the scatter of the next).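

The swap of 4-methoxyphenyl for 3-fluorophenyl on a carbonyl carbon whose other neighbours are an amide-type nitrogen gives the only one-place comparison shown in this series: a 1.4-fold higher number from compound 3 to compound 4 (0.15 log units; within the scatter) is the step read in this assay for this change. At this position, then, one aryl group can stand in for the other with no change that can be told from the usual scatter of this assay, and the comparison sets no order between compound 3 and compound 4. No information given here bears on the reason for this result.

Open, from the compounds shown here alone, is whether an amine, a carboxylic acid or a longer alkyl chain in place of the aryl group on this carbonyl carbon would give a step beyond the scatter. Also open, going by these compounds, is whether the same aryl swap would read alike on a different core.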